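The compounds below may be only part of what the source reports. "The series", "measured", "known", "first", "only" and "open" are said of these compounds alone.

Compound 1, whose structure is `O=C1/C(=C/c2cccc(Cl)c2)c2ccccc2N1c1c(Cl)cccc1Cl`, gives 50 ug/mL in a functional assay on SW-620 cells (Homo sapiens) for cytotoxicity, read by MTT assay, with a stated time of 3 days; on this read-out higher numbers stand for an effect only at larger amounts of compound and lower numbers for an effect already at smaller amounts. Within the data shown here, that is the highest of the two numbers so far; the only other measured compound, compound 2 with the structure `O=C1/C(=C/c2ccc(F)cc2)c2ccccc2N1c1c(Cl)cccc1Cl`, gives 5 ug/mL in this assay. Among the measured compounds shown here, the single step between them, a 10-fold lower number from compound 1 to compound 2 (1.00 log units; beyond the scatter), changes the group on the exocyclic double bond, and it shows that a small change on that ring can move the number by a modest amount.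

Compound 3, with the structure `O=C1/C(=C/c2cccc(Oc3ccccc3)c2)c2ccccc2N1c1c(Cl)cccc1Cl`, differs from compound 1 in one place: phenoxy in place of chloro on an aromatic carbon. For the measured compounds named here, no measured step exchanges a chloro group for a phenoxy group, so nothing here bears directly on this change. The step from compound 1 to compound 2 only tells that changes on this ring are felt in the assay without fixing the direction. The expected outcome is therefore a modest shift toward a lower number, a step of a 2.5-fold lower number from compound 1 to compound 3 (0.40 log units; beyond the scatter), with wide uncertainty. For compound 3 the estimate in this assay is 20 ug/mL, with a range from 5 ug/mL to 80 ug/mL.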

Compound 3, concentration for half-maximal effect: 50 ug/mL
For compound 3 the middle estimate is 2.5-fold (0.40 log units) below the measured one; the range from low to high includes it.
By their numbers in this assay, from the lowest: compound 2; then compounds 1 and 3 (each within the scatter of the next).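

The exchange of chloro for phenoxy gives no change at the digits printed from compound 1 to compound 3 (within the scatter) in this assay even though one heavy atom is replaced by seven, including a six-membered aromatic ring of carbon only. The earlier step, a 10-fold lower number from compound 1 to compound 2 (1.00 log units; beyond the scatter) for 4-fluorophenyl in place of 3-chlorophenyl, changed both the group and its place on the ring, whereas this one changes only the group on the same aromatic carbon, meta to a large group. It shows that at this carbon, a large increase in the size of the group by atom count does not by itself shift the number, and no measurement available here speaks to the reason for this.

The compounds shown leave open whether the earlier step depends on the fluoro group itself or on where that group sits, as fluoro on the carbon that carries chloro and phenoxy here would separate those two changes. They also leave open whether a group of a different kind on this carbon, such as an amine or a carboxylic acid, would be tolerated in the same way as phenoxy.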